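A few compounds are considered here, and "the series" means these few. Any claim that something is new, unique, unknown or untested is made for them only; others in the source may bear on it.

Notes on the series. Compound 1 `CC(=O)OC(C)n1cnc2c(Cl)nc(I)nc21` carries an acetyl on an oxygen on a saturated carbon; in a functional assay on L1210 cells (Mus musculus) for inhibition (on this read-out higher numbers stand for weaker inhibition and lower numbers for stronger inhibition), compound 1 gives 13000 nM. Compound 2 `CC(O)n1cnc2c(Cl)nc(I)nc21` is its hydroxy counterpart, (hydrogen in place of acetyl on an oxygen on a saturated carbon). In this assay compound 2 is reported only as a limit of the assay, > 500000 nM. The step is an at least 38-fold higher number from compound 1 to compound 2 (1.58 log units; beyond the scatter); its size is a lower bound set by the limit of > 500000 nM in this assay, at which 1 of the 3 values shown sits.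

Compound 3 `CC(=O)OC(C)n1cnc2c(S)nc(F)nc21` rests on a different core; how its core differs from the core of compound 1 is not broken down here. In this assay, among the measured compounds shown here, compound 3 gives 226000 nM, the highest of the two numbers known and beyond the scatter from compound 1.

Compound 4 `CC(O)n1cnc2c(S)nc(F)nc21` has not yet been measured in this assay. It derives from compound 3 by hydrogen in place of acetyl on an oxygen on a saturated carbon. The place is described in the same words as for the change from compound 1 to compound 2, so this is the same change, now on the core of compound 3. If it moves compound 4 off compound 3 as far as an at least 38-fold higher number from compound 1 to compound 2 (1.58 log units; beyond the scatter), the result would lie past the limit at which compound 2 sits, so compound 4 is expected to come back as a limit rather than a number more often than not. For compound 4 the expected step is an 8.8-fold higher number from compound 3 to compound 4 (0.95 log units; beyond the scatter), resting on compound 3 at 226000 nM and on the step of an at least 38-fold higher number from compound 1 to compound 2 (1.58 log units; beyond the scatter). The estimate for compound 4 is 2000000 nM, expected to fall between 500000 nM and 20000000 nM.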

Compound 4, half-maximal inhibitory concentration: > 500000 nM
Compound 4: no number, only a limit; the forecaster's own chance of this, stated with the estimate: 85%; the middle value does not contradict the limit.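

In this assay the change from acetoxy to hydroxy gives an at least 2.2-fold higher number from compound 3 to compound 4 (0.34 log units; beyond the scatter), which runs in the same direction as an at least 38-fold higher number from compound 1 to compound 2 (1.58 log units; beyond the scatter). Compound 4 is reported only as a limit of the assay, > 500000 nM, not as a number, and compound 2 sits at the same limit: the limit of > 500000 nM in this assay, at which 2 of the 4 values shown sit. The direction of the change therefore carries from the core of compound 1 to the core of compound 3, but neither step has a fixed size, so the data do not show whether the change is equally large on both cores: the same change on two cores in this assay, an at least 38-fold higher number (1.58 log units; beyond the scatter) from compound 1 to compound 2 and an at least 2.2-fold higher number (0.34 log units; beyond the scatter) from compound 3 to compound 4; the limit leaves it open whether they differ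

The compounds shown leave open how far either hydroxy compound actually lies from its acetoxy partner, since a number on the far side of the limit is missing for both. On these data alone, they also hold only acetoxy and hydroxy at this place, so it remains open whether a longer ester such as propionyloxy, a methyl ether or an amine would follow the acetoxy compounds or the hydroxy compounds.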